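From Methyl to Allyl on Compound 3

A few compounds are considered here, and "the series" means these few. Any claim that something is new, unique, unknown or untested is made for them only; others in the source may bear on it.

In a functional assay on MCF7 cells (Homo sapiens) for inhibition, read by radiometric assay and XTT assay (on this read-out higher numbers stand for weaker inhibition and lower numbers for stronger inhibition), three compounds have results so far. Compound 1 (`CCCCCC[C@@]1(C)SC(O)=CC1=O`) gives only a limit and not a number: > 80 ug/mL is what the assay reports for it. Compound 2 (`C=CCOC1=CC(=O)S[C@]1(C)CCCCCC`) gives 9 ug/mL as its result. Compound 3 (`C=CCC1(C)C(=O)S[C@](C)(CCCCCCCC)C1=O`) stands at 40.5 ug/mL and so holds the higher of the two real numbers. On this read-out that means weaker inhibition than compound 2, and the gap lies beyond the usual scatter of repeated measurements.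

Compound 4 (`C=CCC1(CC=C)C(=O)S[C@](C)(CCCCCCCC)C1=O`) alters compound 3 in one place (vinyl in place of hydrogen on a saturated chain carbon bound to a saturated ring carbon). In words, vinyl takes the place of hydrogen on a saturated chain carbon bound to a saturated ring carbon, which turns a methyl into an allyl. For the measured compounds named here, no measured pair shows this change, so its size in this assay remains an open question. The closest anchor is compound 3 at 40.5 ug/mL and the expectation is no shift beyond the scatter. The expected step is a 1.2-fold lower number from compound 3 to compound 4 (0.06 log units; within the scatter) and it stays small. A result given only as a limit remains possible. Compound 4 is estimated at 35 ug/mL with a likely range from 14 ug/mL to 75 ug/mL in this estimate.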

Compound 4, half-maximal inhibitory concentration: 40.5 ug/mL
Beside the measured number, compound 4's estimate is 1.2-fold (0.06 log units) below it; the range from low to high includes it.
By their numbers in this assay, from the lowest: compound 2; then compounds 3 and 4 (each within the scatter of the next). At a limit, above all of these: compound 1.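

In this assay, turning the methyl into an allyl, with vinyl in place of hydrogen on a saturated chain carbon bound to a saturated ring carbon, gives no change at the digits printed from compound 3 to compound 4 (within the scatter). For the compounds shown here, this is the first direct reading of any change at this place, since compound 1, compound 2 and compound 3 differ from one another in more than one place and the steps among them cannot be read. The flat step is also read between two real numbers, so the ceiling of the assay does not hide a change here, and only compound 1 gives a limit and not a number: the limit of > 80 ug/mL in this assay, at which 1 of the 4 values shown sits.

One step shows only that methyl and allyl read alike at this place, and a carboxylic acid, an amine or a longer chain in place of the allyl could read quite differently. On these data alone, whether the same swap stays flat on the core of compound 2, or with the hexyl-type chain of compound 1 in place of the octyl-type chain of compound 3, also remains open.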